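The source may report more compounds than this note shows. Statements on the series, on what has been measured and on what is new or still open speak of the compounds shown alone.

Working notes on the series of compound 1 `CCCOC(=O)C1=C(C)N(C)C(=O)NC1c1ccco1`, compound 2 `CCCOC(=O)C1=C(C)N(C)C(=O)NC1c1ccoc1` and compound 3 `CC1=C(C(=O)OC(C)(C)C)C(c2ccoc2)NC(=O)N1C`, with compound 4 `CCCOC(=O)C1=C(C)N(C)C(=O)NC1c1cccs1` not yet measured. In an assay on membranes from HEK293 cells for displacement of a labelled ligand from adenosine receptor A2b (Homo sapiens), read by scintillation counting, with a stated time of 30 min, tested at 1 uM (a lower number here means less inhibition, a higher number more inhibition at the concentration tested (going by the name of the read-out)), compound 1 gives 23%, compound 2 gives 2% and compound 3 gives 16%. Compound 2 stands lowest of the three: the step of a number 21 percentage points lower from compound 1 to compound 2 (beyond the scatter) and the step of a number 14 percentage points higher from compound 2 to compound 3 (beyond the scatter) both lie beyond the scatter. Compound 4 arises from compound 2 by thiophen-2-yl in place of furan-3-yl on a saturated ring carbon. Among the compounds with values here, only the step of a number 21 percentage points lower from compound 1 to compound 2 (beyond the scatter) bears on this, since compound 4, like compound 1, carries the ring as a 2-yl group rather than furan-3-yl; a modest upward step is therefore expected. Compound 4 is estimated at 20%, within 5% to 35%. The expected step is a number 18 percentage points higher from compound 2 to compound 4 (beyond the scatter).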

Compound 4, a percentage reported as inhibition, at one concentration (the size of the read-out at that concentration, not a potency): 1%
Beside the measured number, compound 4's estimate is 19 percentage points above it; measured number outside the range, below it.
By their numbers in this assay, from the lowest: compounds 4 and 2 (each within the scatter of the next); then compounds 3 and 1 (each within the scatter of the next).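

In this assay, thiophen-2-yl on the saturated ring carbon does not match furan-2-yl: the change gives a number 22 percentage points lower from compound 1 to compound 4 (beyond the scatter), whereas the change from furan-3-yl gives a number 1 percentage points lower from compound 2 to compound 4 (within the scatter). The 2-yl attachment alone therefore does not go with the higher number of compound 1, as compound 4 shares that attachment; at this position, the hetero atom of the ring counts alongside the point of attachment. No available evidence accounts for this difference.

Still open, going by these compounds, is how thiophen-3-yl, phenyl or a pyridine ring would read at this position. Also open, on these data alone, is whether tert-butyl in place of propyl would give a similar step with furan-2-yl or thiophen-2-yl.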